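Taking the chloro group off compound 2

A few compounds are considered here, and "the series" means these few. Any claim that something is new, unique, unknown or untested is made for them only; others in the source may bear on it.

Compound 1 `COc1ccc(-c2nc3sc(-c4ccccc4)cn3n2)cc1` gives 64%
Compound 2 `Clc1ccc(-c2cn3nc(-c4ccccc4)nc3s2)cc1` gives 13%

Within the data shown here, in a functional assay on SW-620 cells (Homo sapiens) for inhibition, read by sulforhodamine B assay, with a stated time of 48 h, tested at 10 uM (a higher number here means more inhibition of growth at the concentration tested, a lower number less inhibition of growth), compound 2 gives 13% as the lower of the two numbers so far. Compound 1 gives 64% and stands above it by a gap beyond the usual scatter. Among the measured compounds shown here, these two compounds differ in more than one place, so no single-change step is available as a guide.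

Compound 3 `c1ccc(-c2nc3sc(-c4ccccc4)cn3n2)cc1` departs from compound 2 in one place only, and hydrogen in place of chloro on an aromatic carbon is the whole difference. Hydrogen takes the place of chloro on an aromatic carbon, para to a large group, so 4-chlorophenyl becomes phenyl. Nothing measured here shows this exact change, so the expectation is loose. Compound 2 at 13% has far more room to rise than to fall, which makes a rise more likely than a drop. The estimated change in this assay is a number 15 percentage points higher from compound 2 to compound 3 (beyond the scatter) as an expected upward step of moderate size that may only just clear the scatter. For compound 3 the estimated value is 28% with an expected range from 5% to 55% around it.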

Compound 3, percent growth inhibition at one concentration: 5%
The estimate for compound 3 lay 23 percentage points above the measured number, within the range that was stated.
By their numbers in this assay, from the lowest: compounds 3 and 2 (each within the scatter of the next); then compound 1.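

In this assay, the change from 4-chlorophenyl to phenyl gives a number 8 percentage points lower from compound 2 to compound 3 (within the scatter) and so does not separate chloro from hydrogen at this place. Hydrogen in place of methoxy on an aromatic carbon gives a number 59 percentage points lower from compound 1 to compound 3 (beyond the scatter) and is a large loss, so among these three compounds, clear growth inhibition appears only in compound 1, the one that carries methoxy. No other measurement shown here accounts for the difference in size between these two steps.

Going by these compounds, compound 1 and compound 2 differ in more than one place, so it remains open whether chloro would behave like hydrogen at the place that holds methoxy in compound 1, and whether methoxy would restore the inhibition at the place that holds chloro in compound 2. On these data alone, it also remains open how specific the result is to methoxy, and a hydroxyl group, an ethoxy group or an amine at that same place would show whether other groups can take its role.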